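A few compounds are considered here, and "the series" means these few. Any claim that something is new, unique, unknown or untested is made for them only; others in the source may bear on it.

Measured so far in an assay on cells for inhibition of MAP kinase-interacting serine/threonine-protein kinase 1 (Homo sapiens), read by mobility shift assay, with stated times of 10 min and 60 min, in the presence of a further agent that is not named here; a higher number here means a weaker inhibitor, a lower number a stronger inhibitor:
Compound 1 `CCOc1cc(-c2cccnc2)ccc1C(N)=O` gives 2200 nM.
Compound 2 `CNC(=O)c1ccc(-c2cccnc2)cc1` gives 292000 nM.
Compound 3 `Cn1cc(-c2cncc(-c3ccc(C(N)=O)cc3)c2)cn1` gives 800 nM.

Among these three numbers in this assay, compound 1 stands second highest. Its nearest neighbour is compound 3, whose lower number lies beyond the scatter; compound 2 is furthest away, with a higher number that also lies beyond the scatter. The account now turns to compound 4 `COc1cc(-c2cccnc2)ccc1C(N)=O`, which has not yet been measured. Set against compound 1, the change is hydrogen in place of methyl on a saturated chain carbon bound to an oxygen on an aromatic ring. Going by the values given here, no pair of measured compounds differs in this one place, so there is no measured step to lean on; compound 2 and compound 3 differ from compound 1 elsewhere in the structure, and their values show only how wide the spread across this small set is. With nothing to indicate a direction, the step from compound 1 to compound 4 in this assay is expected to be small, a 1.1-fold higher number from compound 1 to compound 4 (0.06 log units; within the scatter), within the usual scatter. Compound 4 is therefore estimated at 2500 nM in this assay, with a range from 900 nM to 7000 nM.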

Compound 4, half-maximal inhibitory concentration: 2800 nM
For compound 4 the middle estimate is 1.1-fold (0.05 log units) below the measured one, within the range that was stated.
By their numbers in this assay, from the lowest: compound 3; then compounds 1 and 4 (each within the scatter of the next); then compound 2.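

In this assay, going by these compounds alone, the change from ethoxy to methoxy gives a 1.3-fold higher number from compound 1 to compound 4 (0.10 log units; within the scatter) and this is the first measured step at this position, one that lies within the scatter. Removing the methyl from the end of the chain therefore leaves the read-out effectively unchanged, and neither compound can be ranked above the other. Nothing measured here offers an explanation for how closely the two compounds agree.

What a longer chain or an amine would do at this position remains open, and the two alkoxy groups shown span only a narrow range of sizes. On these data alone, it also remains open how either group would compare with a bare hydrogen on the aromatic ring, so the importance of the ether oxygen itself cannot be judged.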